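Working notes: from compound 1 to compound 4

The source may hold more compounds than are shown below. What is called first, only, known or untested is meant among the compounds shown, and "the series" means these compounds.

Values in a functional assay on OVCAR-3 cells (Homo sapiens) for antiproliferative activity, read by spectrophotometry, with a stated time of 2 days (on this read-out higher numbers stand for weaker inhibition of growth and lower numbers for stronger inhibition of growth), so far
Compound 1 `COc1ccc(Nc2ncc(C(F)(F)F)c(N3Cc4cccc(N(C)S(C)(=O)=O)c4C3)n2)cc1C(F)(F)F` gives > 30000 nM as a limit
Compound 2 `Cc1ccc(Nc2ncc(C(F)(F)F)c(N3Cc4cccc(N(C)S(C)(=O)=O)c4C3)n2)c(Cl)c1` gives > 30000 nM as a limit
Compound 3 `CN(c1cccc2c1CN(c1nc(Nc3ccc(Nc4ccccc4)cc3)ncc1C(F)(F)F)C2)S(C)(=O)=O` gives > 50000 nM as a limit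

Compound 1 stands at the limit > 30000 nM and carries no number. The whole series offers only limits, namely the limit of > 30000 nM in this assay, at which 2 of the 3 values shown sit, and the limit of > 50000 nM in this assay, at which 1 of the 3 values shown sits, with no measured number beside them.

Compound 4 `Cc1cc(F)ccc1Nc1ncc(C(F)(F)F)c(N2Cc3cccc(N(C)S(C)(=O)=O)c3C2)n1` keeps the core of compound 1 and carries 4-fluoro-2-methylphenyl in place of 4-methoxy-3-(trifluoromethyl)phenyl on a nitrogen on an aromatic ring.

Among the measured compounds shown here, one measured step bears on this change, a step that the two limits leave unreadable from compound 1 to compound 2 with 2-chloro-4-methylphenyl as the entering group at the same place. Its size cannot be read. Compound 2 rests at the limit > 30000 nM after its replacement, and that is the closest guide to compound 4 in the series. Compound 3 also rests at a limit, > 50000 nM with a different group at that nitrogen.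

The step expected in this assay is a number no higher from compound 1 to compound 4 (the limit leaves the size open) and no direction beyond the scatter can be expected from these limits. Compound 4 is estimated at 30000 nM with an expected range from 10000 nM to 60000 nM and a limit rather than a number is the likely result.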

Compound 4, concentration for 50% growth inhibition: > 30000 nM
Compound 4: only a limit was reported (the forecaster's own chance of this, stated with the estimate: 80%); the middle value lies on the limit itself.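

In this assay compound 4 gives > 30000 nM, which is a limit, and the steps to it from compound 1 and from compound 2 cannot be read. The compounds shown leave open whether any group on that nitrogen on an aromatic ring would give a measured number rather than a limit in this assay.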